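The source may report more compounds than this note shows. Statements on the series, on what has been measured and on what is new or still open speak of the compounds shown alone.

Within the data shown here, in an assay on frontal cortex for displacement of a labelled ligand from corticotropin-releasing factor receptor 1 (Rattus norvegicus), with a stated time of 2 h (a higher number here means a weaker inhibitor, a lower number a stronger inhibitor), compound 2 `COc1nc(C)c(Nc2nc(Cl)cn([C@H](COC(=O)c3cccnc3)C3CC3)c2=O)cc1C` gives 5.2 nM, the higher of the two numbers measured so far, while compound 1 `COc1nc(C)c(Nc2nc(Cl)cn([C@H](COC(=O)c3ccccc3)C3CC3)c2=O)cc1C` gives 1.5 nM. Compound 3 `COc1nc(C)c(Nc2nc(Cl)cn([C@H](COC(=O)Nc3ccccc3)C3CC3)c2=O)cc1C` differs from compound 2 by anilino in place of pyridin-3-yl on a carbonyl carbon. Among the measured compounds shown here, the only measured step at this carbonyl carbon is a 3.5-fold higher number from compound 1 to compound 2 (0.54 log units; beyond the scatter), so a change of the ring on this carbon has moved the number beyond the scatter before. Since compound 3 carries a carbon-only ring, as compound 1 does, a modest move back toward the number of compound 1 is expected, giving a 1.7-fold lower number from compound 2 to compound 3 (0.24 log units; within the scatter). Compound 3 is therefore estimated at 3 nM, within 1 nM to 12 nM.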

Compound 3, half-maximal inhibitory concentration: 1.5 nM
Compound 3: middle estimate off by 2.0-fold (0.30 log units), on the high side; low and high end bracket the measured number.
By their numbers in this assay, from the lowest: compounds 1 and 3 (each within the scatter of the next); then compound 2.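

In this assay, anilino in place of pyridin-3-yl on this carbonyl carbon gives a 3.5-fold lower number from compound 2 to compound 3 (0.54 log units; beyond the scatter), whereas anilino in place of phenyl gives no change at the digits printed from compound 1 to compound 3 (within the scatter). The position therefore accepts a carbon-only ring attached either directly or through the anilino nitrogen, and among these three compounds only the pyridin-3-yl ring stands apart. Nothing available accounts for this result. Still open, on these data alone, is whether a saturated ring such as cyclohexyl would fit here, and what a methyl group on the anilino nitrogen would do to the number.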